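This account rests on a few compounds, and the source may have more. Where it says the series, first, only, none or still open, it means among the compounds named here.

Measured so far in an assay for displacement of a labelled ligand from Adrenergic receptor alpha-1 (Homo sapiens); on this read-out higher numbers stand for weaker inhibition and lower numbers for stronger inhibition:
compound 1 `Cn1c(=O)cnn(CCCCN2CCN(c3ccccc3OCCCF)CC2)c1=O` — 280 nM
compound 2 `CN(C)c1ccccc1N1CCN(CCCCn2ncc(=O)n(C)c2=O)CC1` — 350 nM
compound 3 `Cn1c(=O)cnn(CCCCN2CCN(c3c(Br)cccc3C#N)CC2)c1=O` — 450 nM

The three numbers sit close together. Compound 3 gives the highest of them, yet the two steps that separate it from the others, a 1.3-fold higher number from compound 2 to compound 3 (0.11 log units; within the scatter) and before that a 1.3-fold higher number from compound 1 to compound 2 (0.10 log units; within the scatter), are both within the scatter, so no order among the three can be read from this assay.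

The unmeasured compound 4 `Cn1c(=O)cnn(CCCCN2CCN(c3cccc(F)n3)CC2)c1=O` differs from compound 3 in one place: 6-fluoropyridin-2-yl in place of 2-bromo-6-cyanophenyl on an amine nitrogen in a ring. Both steps seen so far bear on it. The step from compound 1 to compound 2 swaps one substituent on the aromatic ring that hangs on the ring nitrogen, and gave a 1.3-fold higher number from compound 1 to compound 2 (0.10 log units; within the scatter). The step from compound 2 to compound 3 exchanges the whole aromatic group on that ring nitrogen, and gave a 1.3-fold higher number from compound 2 to compound 3 (0.11 log units; within the scatter). Neither left the scatter. Among the measured compounds shown here, the change to compound 4 is of the second kind, again a whole-group exchange on the same ring nitrogen, but it also replaces a carbon-only ring with a ring holding one hetero atom, which no measured pair covers; the uncertainty is therefore set somewhat wider than the spread seen so far.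

On this basis no step beyond the scatter is expected in this assay, and the estimated step is no change at the digits printed from compound 3 to compound 4 (within the scatter). Compound 4 is expected to give about 450 nM, with a range from 150 nM to 1400 nM.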

Compound 4, inhibition constant: > 10000 nM
Compound 4: a limit, no number; the forecaster's own chance of this, stated with the estimate: 3%; middle value at least 22-fold (1.34 log units) from the limit.
By their numbers in this assay, from the lowest: compounds 1, 2 and 3 (each within the scatter of the next). At a limit, above all of these: compound 4.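

In this assay, the aromatic group on the amine nitrogen in a ring tolerated the earlier exchange among the compounds shown, but not this one: 6-fluoropyridin-2-yl in place of 2-bromo-6-cyanophenyl gives an at least 22-fold higher number from compound 3 to compound 4 (1.34 log units; beyond the scatter). The same group in place of 2-(dimethylamino)phenyl gives an at least 28-fold higher number from compound 2 to compound 4 (1.45 log units; beyond the scatter), so the loss appears against both aromatic groups compared and not against one alone. The reading for compound 4 is a limit and not a number: the limit of > 10000 nM in this assay, at which 1 of the 4 values shown sits.

The change to compound 4 alters the ring, its substituents and the halogen in a single step, so the compounds shown cannot assign the loss to the ring hetero atom, to the fluorine or to the absence of the bromine and nitrile. A plain phenyl group, or a pyridin-2-yl group carrying a bromine or a nitrile instead of the fluorine, would separate these contributions on the same core.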